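The source may report more compounds than this note shows. Statements on the series, on what has been measured and on what is new or still open speak of the compounds shown alone.

Compound 1, `Cc1noc(C)c1C(c1ccccc1)N1CCN(c2ncnc3c2cnn3-c2ccccc2)CC1`, in a functional assay on cells (Rhabdomyosarcoma cell, Homo sapiens) for cytotoxicity; a higher number here means a weaker inhibitor, a lower number a stronger inhibitor: > 25000 nM, a limit of the assay and not a number.
Compound 2, `Cc1ccsc1C(c1ccccn1)N1CCN(c2ncnc3c2cnn3-c2ccccc2)CC1`, in this assay: > 25000 nM, likewise a limit of the assay.
Compound 3, `Cc1ccccc1C(c1sccc1C)N1CCN(c2ncnc3c2cnn3-c2ccccc2)CC1`, in this assay: > 25000 nM, likewise a limit of the assay.

Among the measured compounds shown here, compound 1 thus stands at the limit of the assay, and so do the other two measured compounds; there is the limit of > 25000 nM in this assay, at which 3 of the 3 values shown sit, and no compound gives a number. The unmeasured compound 4 is `c1ccc(C(c2ccncc2)N2CCN(c3ncnc4c3cnn4-c3ccccc3)CC2)cc1`. It differs from compound 1 in one place: pyridin-4-yl in place of 3,5-dimethyl-1,2-oxazol-4-yl on a saturated chain carbon bound to an amine nitrogen in a ring and an aromatic carbon. For the measured compounds named here, the only measured step that bears on a change at this position is a step that the two limits leave unreadable from compound 2 to compound 3, and because both of its ends sit at the limit of > 25000 nM in this assay, at which 3 of the 3 values shown sit, its size cannot be read. Going by the values given here, no measured step in this set gives a readable size, so nothing in the numbers points to a gain or a loss beyond the scatter for compound 4. Compound 4 is therefore expected to sit at the limit as well, with a step that the limit leaves unreadable from compound 1 to compound 4 taken as no readable step. The estimate for compound 4 in this assay is 40000 nM, in the range 10000 nM to 150000 nM.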

Compound 4, half-maximal inhibitory concentration: > 25000 nM
Compound 4: a limit, no number; the forecaster's own chance of this, stated with the estimate: 85%; the middle value lies beyond the limit too.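

Between compound 1 and compound 4 no step can be read, since both stand at a limit of the assay and neither gives a number: the limit of > 25000 nM in this assay, at which 4 of the 4 values shown sit.
The compounds shown leave open whether any change on the shared core would give a number in this assay at all.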